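Swapping azetidine for pyrrolidine in compound 3

A few compounds are considered here, and "the series" means these few. Any claim that something is new, unique, unknown or untested is made for them only; others in the source may bear on it.

Compounds in an ADME assay on a cell-free system (plasma, Rattus norvegicus) for protein binding:
- compound 1 `CNc1nccc(N2CC[C@H](NC(=O)Nc3ccc(Cl)c(C(F)(F)F)c3)C2)n1`: 99.7%
- compound 2 `CNc1nccc(N2CC[C@H](NC(=O)Nc3ccc(CN4CCC4)c(C(F)(F)F)c3)C2)n1`: 89.2%
- compound 3 `CNc1nccc(N2CC[C@H](NC(=O)Nc3ccc(CN4CCCC4)c(C(F)(F)F)c3)C2)n1`: not yet measured

Of the two measured compounds, compound 2 stands highest in unbound fraction, at 89.2%. The next structure differs from it as follows: pyrrolidin-1-yl in place of azetidin-1-yl on a saturated chain carbon bound to an aromatic carbon. In words, pyrrolidin-1-yl takes the place of azetidin-1-yl on a saturated chain carbon bound to an aromatic carbon. Within the data shown here, only one measured step bears on this, a 36-fold higher unbound fraction from compound 1 to compound 2 (1.56 log units; beyond the scatter), a large change in which (azetidin-1-yl)methyl replaced chloro on an aromatic carbon. Among the measured compounds shown here, that step exchanged a different pair of groups, and no measured step compares two such rings, so it is only a loose guide. A change of that size is not expected here. The expected step is a 1.2-fold lower unbound fraction from compound 2 to compound 3 (0.08 log units; within the scatter), which would leave the unbound fraction close to where it stands. For compound 3 the estimated value in this assay is 91%, with an expected range from 84% to 95.5%.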

Compound 3, plasma protein binding: 87.8%
Compound 3: the middle estimate sits 1.4-fold (0.13 log units) (unbound fraction) below what was measured; low and high end bracket the measured number.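

In this assay, pyrrolidin-1-yl in place of azetidin-1-yl gives a 1.1-fold higher unbound fraction from compound 2 to compound 3 (0.05 log units; within the scatter), so on this saturated chain carbon bound to an aromatic carbon the four-membered and five-membered rings cannot be told apart. The large step away from chloro is also not confined to the azetidine: a 41-fold higher unbound fraction from compound 1 to compound 3 (1.61 log units; beyond the scatter) stands alongside a 36-fold higher unbound fraction from compound 1 to compound 2 (1.56 log units; beyond the scatter), and the same read-out now holds for two ring sizes. No evidence is at hand on what lies behind these numbers.

The compounds shown leave open whether a larger ring such as piperidin-1-yl, a ring with a second hetero atom such as morpholin-4-yl, or an open-chain dimethylamino group would read like these two rings. They also leave open whether the ring nitrogen matters at all, which a cyclopentylmethyl group at this place could test.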